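The source may report more compounds than this note shows. Statements on the series, on what has been measured and on what is new or still open speak of the compounds shown alone.

Compound 1 `CC(C)=CCOc1cccc(O)c1C(=O)/C=C/c1ccc(O)cc1`: > 30000 nM
Compound 2 `CC(C)CCOc1cccc(O)c1C(=O)/C=C/c1ccc(O)cc1`: 12400 nM

The test here is a functional assay on NUGC-3 cells (Homo sapiens) for antiproliferative activity, read by sulforhodamine B assay; a lower number here means a stronger inhibitor of growth, a higher number a weaker inhibitor of growth. For compound 1, > 30000 nM is a limit of the assay, not a number. Among the compounds with values here, compound 2, at 12400 nM, gives the only true number so far. Compound 3 `O=C(/C=C/c1ccc(O)cc1)c1c(O)cccc1OCCC1CCCC1` carries cyclopentyl in place of isopropyl on a saturated chain carbon, two bonds along the chain from an oxygen on an aromatic ring. Within the data shown here, only one measured step touches this chain: an at least 2.4-fold lower number from compound 1 to compound 2 (0.38 log units; beyond the scatter), and it rests on a limit. That is thin support, so only a small change is expected, a 1.4-fold lower number from compound 2 to compound 3 (0.14 log units; within the scatter), within the scatter. For compound 3 the estimated value is 9000 nM, with an expected range of 3500 nM to 22000 nM.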

Compound 3, concentration for 50% growth inhibition: 3200 nM
Estimate against measurement, compound 3: 2.8-fold (0.45 log units) above, and the stated range ends above it.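

The chain end is more sensitive than the first step suggested: in this assay, cyclopentyl in place of isopropyl gives a 3.9-fold lower number from compound 2 to compound 3 (0.59 log units; beyond the scatter), a clear gain in growth inhibition from a ring at this spot. Set against compound 1, the change gives an at least 9.3-fold lower number from compound 1 to compound 3 (0.97 log units; beyond the scatter), but that step rests on a limit, not a number: the limit of > 30000 nM in this assay, at which 1 of the 3 values shown sits.

As far as these compounds go, whether the gain comes from the ring itself or simply from the added carbons stays open. So does how a cyclohexyl ring, a longer chain or an amine at this chain end would behave.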